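The source may report more compounds than this note shows. Statements on the series, on what has been measured and on what is new or still open speak of the compounds shown alone.

Compound 1 `Cn1c(-c2ccc(-c3cncnc3)cc2)nnc1C1(c2ccc(Cl)cc2)CCC1` and compound 2 `Cn1c(-c2ccc(N)cc2Cl)nnc1C1(c2ccc(Cl)cc2)CCC1` share the same core and differ only in the aromatic group attached to the five-membered aromatic ring with 3 nitrogen. In a functional assay on the whole organism (strain ICR) for inhibition, with Mus musculus as the target, read by scintillation counting, with a stated time of 4 h, at a dose of 10 mg/kg by the oral route (on this read-out lower numbers stand for less inhibition and higher numbers for more inhibition at the one dose given (going by the name of the read-out)), compound 1 gives 46%. In this assay compound 2 gives 90%, the higher of the two numbers measured; its nearest neighbour is compound 1, whose number lies lower by a gap that is beyond the usual scatter of this kind of measurement.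

Compound 3 `Cn1c(-c2ccccc2)nnc1C1(c2ccc(Cl)cc2)CCC1` has not yet been measured. It differs from compound 2 in one place: phenyl in place of 4-amino-2-chlorophenyl on an aromatic carbon. The 4-amino-2-chlorophenyl of compound 2 leaves and a bare phenyl enters, so the single hydrogen-bond donor and the single hydrogen-bond acceptor of that group are lost.

Within the data shown here, no pair of measured compounds shows this exact change, so no measured step can guide the expectation directly. Because compound 1, which carries a different aromatic group at the same place, gives 46%, a step downward from compound 2 to compound 3 of a number 30 percentage points lower from compound 2 to compound 3 (beyond the scatter) in this assay is expected. Compound 3 is estimated to give 60% in this assay, with a likely range from 30% to 85%.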

Compound 3, a percentage reported as inhibition, in the whole organism at one dose (the size of the read-out at that dose, not a potency): 29%
Beside the measured number, compound 3's estimate is 31 percentage points above it; measured number outside the range, below it.
By their numbers in this assay, from the lowest: compound 3; then compound 1; then compound 2.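

In this assay the bare phenyl on the aromatic carbon of the shared core turns out to be the low point of the three compounds, which the first two compounds alone could not show. Taking away the amino and chloro substituents together, so that phenyl replaces 4-amino-2-chlorophenyl, gives a number 61 percentage points lower from compound 2 to compound 3 (beyond the scatter), a large step, while hydrogen in place of pyrimidin-5-yl gives a number 17 percentage points lower from compound 1 to compound 3 (beyond the scatter), a more modest one. Both steps run the same way, so among these compounds each of the two substituted rings reads higher than the bare phenyl, though no independent evidence bears on why this happens.

Compound 2 differs from compound 3 by the amino group and the chlorine at once, so these compounds leave open how much of the large step belongs to each of the two. They also leave open how a phenyl ring carrying a different group, such as a methoxy group or a carboxylic acid, would read at this dose.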